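This account rests on a few compounds, and the source may have more. Where it says the series, first, only, none or still open, it means among the compounds named here.

Measured in a physicochemical assay for lipophilicity, using the shake flask method, in phosphate buffer, measured as octanol-water partition, with a stated time of 24 h, at pH 7.4; a lower number here means a more polar compound, a higher number a more lipophilic compound:
- compound 1 `O=S1(=O)CC(c2cccc(F)c2)c2c(C3CC3)nn(-c3ccccc3F)c2O1`: 2.86
- compound 2 `Cc1cc(C2CS(=O)(=O)Oc3c2c(C)nn3-c2ccccc2F)ccc1Br`: 2.26

Of these two, compound 2 at 2.26 holds the lower value, and the gap to compound 1 at 2.86 lies beyond the scatter. These two compounds differ in more than one place, however, so their gap cannot be read as the measure of any single change.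

The next compound, compound 3 `Cc1cc(C2CS(=O)(=O)Oc3c2c(C2CC2)nn3-c2ccccc2F)ccc1Br`, departs from compound 2 in one place: cyclopropyl in place of methyl on an aromatic carbon. It has cyclopropyl in place of methyl on an aromatic carbon of the five-membered aromatic ring with 2 nitrogen.

Among the measured compounds shown here, no measured pair shows this change alone, so the expectation rests on thin evidence. Compound 1, which also carries cyclopropyl on that carbon, gives 2.86, and this value points upward in this assay. A rise beyond the scatter is therefore expected.

The estimated change is a number 0.64 log units higher from compound 2 to compound 3 (beyond the scatter).

For compound 3 the estimated value is 2.9, with an expected range from 2.5 to 3.3.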

Compound 3, partition coefficient: 2.72
The estimate for compound 3 lay 0.18 log units above the measured number; the range from low to high includes it.
By their numbers in this assay, from the lowest: compound 2; then compounds 3 and 1 (each within the scatter of the next).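

Seen alone for the first time, cyclopropyl in place of methyl on an aromatic carbon of the five-membered aromatic ring with 2 nitrogen gives a number 0.46 log units higher from compound 2 to compound 3 (beyond the scatter) in this assay and so puts a size on a change that the earlier pair, differing in more than one place, could not isolate. With cyclopropyl held at this position, the other single change, 4-bromo-3-methylphenyl in place of 3-fluorophenyl on a saturated ring carbon, gives a number 0.14 log units lower from compound 1 to compound 3 (within the scatter) and thus leaves these two groups unresolved in this measurement, so the gap first seen between compound 1 and compound 2 tracks the step at the aromatic carbon rather than any separable step at the saturated ring carbon. No independent information bears on why either step has the size it has.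

The compounds shown leave open whether the step from methyl to cyclopropyl keeps its size when 3-fluorophenyl sits on the saturated ring carbon. They also leave open how this assay would read with an amine, a carboxylic acid or a longer alkyl chain on the same aromatic carbon.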